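Swapping furan for hydroxyphenyl on an amide carbonyl

The compounds below may be only part of what the source reports. "The series", "measured", "known", "first", "only" and "open" are said of these compounds alone.

In a toxicity assay on THP-1 cells (Homo sapiens) for inhibition (on this read-out higher numbers stand for lower toxicity in this test and lower numbers for higher toxicity in this test), compound 1, with the structure `COc1ccc(-c2cnc(NC(=O)c3ccco3)n2C)cc1`, gives > 100000 nM, which is a limit of the assay rather than a measured number. Two companion compounds were tested as well. Compound 2, with the structure `Cn1c(-c2ccccc2Br)cnc1NC(=O)c1ccc(F)cc1`, gives > 100000 nM, again a limit. Compound 3, with the structure `COc1cccc(-c2cnc(NC(=O)c3ncc[nH]3)n2C)c1`, gives > 100000 nM, also a limit. All three therefore sit at one point: the limit of > 100000 nM in this assay, at which 3 of the 3 values shown sit.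

The new compound, compound 4, has the structure `COc1ccc(-c2cnc(NC(=O)c3ccc(O)cc3)n2C)cc1`. It differs from compound 1 in a single place: 4-hydroxyphenyl in place of furan-2-yl on a carbonyl carbon. Among the measured compounds shown here, no step between two measured compounds has been recorded, so the expectation rests only on where the three measured compounds stand. Since every value shown sits at the limit of > 100000 nM in this assay, at which 3 of the 3 values shown sit, the change is expected to bring no step beyond the usual scatter of this assay. The step of a number no higher from compound 1 to compound 4 (the limit leaves the size open) is what is expected. Compound 4 is estimated at 100000 nM, within 40000 nM to 300000 nM, and most likely it too will be reported only as a limit.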

Compound 4, half-maximal cytotoxic concentration: > 100000 nM
Compound 4 gave a limit, no number; the forecaster's own chance of this, stated with the estimate: 80%; the middle value sits exactly at the limit.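

Among the compounds shown here, compound 1 and compound 4 both stop at a limit in this assay, so no step between them can be read. The compounds shown leave open whether any change to this series would give a measured number, as all of them stand at one point: the limit of > 100000 nM in this assay, at which 4 of the 4 values shown sit.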